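The compounds below may be only part of what the source reports. "The series", "measured", "known", "first", "only" and "open" are said of these compounds alone.

The measured compounds are:

compound 1, `CS(=O)(=O)N1CC(CCl)c2ccc(O)cc21`, which in a functional assay on EMT6 cells (Mus musculus) for cytotoxicity, with a stated time of 4 h (on this read-out higher numbers stand for weaker inhibition and lower numbers for stronger inhibition), gives 7700 nM;
compound 2, `CNc1ccc2c(c1)N(S(C)(=O)=O)CC2CCl`, which in this assay gives 13000 nM;
compound 3, `CN(C)c1ccc2c(c1)N(S(C)(=O)=O)CC2CCl`, which in this assay gives 20000 nM.

Compound 3 has the highest of these three numbers. Of the two steps that end at it, one is a 1.5-fold higher number from compound 2 to compound 3 (0.19 log units; within the scatter), so those two compounds cannot be told apart; the other is a 2.6-fold higher number from compound 1 to compound 3 (0.41 log units; beyond the scatter), a modest step that does exceed the usual scatter. The step of a 1.7-fold higher number from compound 1 to compound 2 (0.23 log units; within the scatter) is also within the scatter.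

Compound 4 is `CSSc1ccc2c(c1)N(S(C)(=O)=O)CC2CCl`. It differs from compound 3 as follows: (methylsulfanyl)sulfanyl in place of dimethylamino on an aromatic carbon. All three measured steps change the group at this same aromatic carbon, and none of them is large; none of them, however, involves a sulfur-bearing group, so the guidance is indirect. A small step, most likely none beyond the scatter, is expected in this assay. The expected step is a 1.3-fold lower number from compound 3 to compound 4 (0.12 log units; within the scatter). Compound 4 is thus estimated at 15000 nM, with a range from 5000 nM to 45000 nM.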

Compound 4, half-maximal inhibitory concentration: > 50000 nM
Compound 4: only a limit was reported; the forecaster's own chance of this, stated with the estimate: 10%; middle value at least 3.3-fold (0.52 log units) away from the limit.
By their numbers in this assay, from the lowest: compounds 1, 2 and 3 (each within the scatter of the next, the first and the last beyond it). At a limit, above all of these: compound 4.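

Among compounds 1, 2 and 3, exchanging hydroxy, methylamino and dimethylamino on this aromatic carbon produced at most a modest step in this assay, and none of these groups contains sulfur. Compound 4 gives only a limit of the assay, not an exact number: the limit of > 50000 nM in this assay, at which 1 of the 4 values shown sits. Even so, (methylsulfanyl)sulfanyl at this position gives an at least 2.5-fold higher number from compound 3 to compound 4 (0.39 log units; beyond the scatter), an at least 3.8-fold higher number from compound 2 to compound 4 (0.58 log units; beyond the scatter) and an at least 6.4-fold higher number from compound 1 to compound 4 (0.81 log units; beyond the scatter), so this change weakens inhibition beyond the scatter against all three earlier groups, which the earlier steps could not show for a sulfur-bearing group.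

From the compounds shown here alone, how far past the limit compound 4 lies remains open, and with it the full size of these steps. Also open, going by these compounds, is whether a simple methylsulfanyl group or a longer chain such as (ethylsulfanyl)sulfanyl would behave the same way.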